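The compounds below may be only part of what the source reports. "The series", "measured", "known", "first", "only" and "open" are said of these compounds alone.

Of the compounds shown here, three sharing one core have been tested in a functional assay on cells (Platelet, Homo sapiens) for inhibition; a higher number here means a weaker inhibitor, a lower number a stronger inhibitor. Compound 1 `CCOC(=O)c1ccc(-c2nn(C)c3ccccc23)cc1` gives 270 nM, the second highest of the three numbers. Compound 2 `CCOC(=O)c1ccc(-c2nn(Cc3ccccc3F)c3ccccc23)cc1` gives 110 nM, and compound 3 `CCOC(=O)c1ccc(-c2nn(-c3ccco3)c3ccccc23)cc1` gives 340 nM. Compound 4 `CCOC(=O)c1ccc(-c2nn(-c3ccccc3)c3ccccc23)cc1` has not yet been measured; its change from compound 1 is phenyl in place of methyl on an aromatic nitrogen. Among the compounds with values here, two measured steps bear on this. The step of a 1.3-fold higher number from compound 1 to compound 3 (0.10 log units; within the scatter) placed an aromatic ring directly on the same nitrogen and stayed within the scatter. The step of a 2.5-fold lower number from compound 1 to compound 2 (0.39 log units; beyond the scatter) attached a ring through a saturated chain carbon and gave a modest gain, while a 3.1-fold higher number from compound 2 to compound 3 (0.49 log units; beyond the scatter) ran the other way. As with compound 3, the ring sits directly on the nitrogen in compound 4, so no step beyond the scatter is expected: a 1.0-fold lower number from compound 1 to compound 4 (0.02 log units; within the scatter). Compound 4 is therefore estimated at 260 nM, within a range of 110 nM to 620 nM.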

Compound 4, half-maximal inhibitory concentration: 2640 nM
The estimate for compound 4 lay 10-fold (1.01 log units) below the measured number; the whole stated range lies below it.
By their numbers in this assay, from the lowest: compound 2; then compounds 1 and 3 (each within the scatter of the next); then compound 4.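

In this assay, aromatic rings on the aromatic nitrogen do not all behave alike: phenyl in place of methyl weakens inhibition (a 9.8-fold higher number from compound 1 to compound 4 (0.99 log units; beyond the scatter)), and so does phenyl in place of furan-2-yl (a 7.8-fold higher number from compound 3 to compound 4 (0.89 log units; beyond the scatter)). The ring's identity therefore matters at this position, and the widest gap comes with phenyl in place of 2-fluorobenzyl (a 24-fold higher number from compound 2 to compound 4 (1.38 log units; beyond the scatter)). No supporting measurement explains this loss. Still open, as far as these compounds go, is whether plain benzyl without fluorine matches 2-fluorobenzyl, and whether a longer chain such as propyl or a pyridine ring on this nitrogen tracks methyl or phenyl.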